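The source may report more compounds than this note shows. Statements on the series, on what has been measured and on what is new or still open speak of the compounds shown alone.

Of the compounds shown here, three have so far been measured in an assay on cell membranes for displacement of a labelled ligand from Neuronal acetylcholine receptor; alpha4/beta2 (Rattus norvegicus), read by scintillation counting; on this read-out higher numbers stand for weaker inhibition and lower numbers for stronger inhibition. Compound 1, `CN1CCC[C@H]1COc1cncc(O)c1`, gives 3.7 nM in this assay. Compound 2, `CN1CC[C@H]1COc1cccc(O)c1`, gives 8.5 nM in this assay. Compound 3, `COc1ncccc1OC[C@@H]1CCCN1C`, gives 7280 nM in this assay. Among these three numbers compound 2 stands second highest: its nearest neighbour is compound 1, whose number is lower by a margin beyond the usual scatter, and the furthest is compound 3, whose number is far higher, again well beyond the scatter.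

The step now followed leads from compound 2 to compound 4, `CN1CC[C@H]1COc1ccccc1`, which has not yet been measured in this assay. The two structures differ in one place: hydrogen in place of hydroxy on an aromatic carbon. The hydroxy group that is removed carries both a hydrogen-bond donor and a hydrogen-bond acceptor, and nothing takes its place but a hydrogen atom.

For the measured compounds named here, no pair of measured compounds here differs only in this way, so the size of the step cannot be read off from the numbers at hand. The change is expected to weaken binding in this assay by a clear margin, a step of a 35-fold higher number from compound 2 to compound 4 (1.55 log units; beyond the scatter) beyond the scatter. On that basis compound 4 is estimated to give 300 nM in this assay, with a range from 40 nM to 3000 nM.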

Compound 4, inhibition constant: 101 nM
Compound 4: middle estimate off by 3.0-fold (0.47 log units), on the high side, within the range that was stated.
By their numbers in this assay, from the lowest: compound 1; then compound 2; then compound 4; then compound 3.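

In this assay, putting hydrogen in place of the hydroxy group on this aromatic carbon, meta to a group of 7 heavy atoms, gives a 12-fold higher number from compound 2 to compound 4 (1.07 log units; beyond the scatter), a large step beyond the usual scatter. For the compounds shown here, this is the first direct sign that the hydroxy group at this position contributes substantially to binding, yet it is not essential for measurable binding, as compound 4 still gives 101 nM. The data shown contain no independent measurement that explains which feature of the hydroxy group accounts for this loss.

As far as these compounds go, it remains open whether a methoxy group, an amine or a fluorine atom on the same carbon would bring the number back towards that of compound 2, which would help separate what the hydroxy group contributes from the mere presence of a substituent there. From the compounds shown here alone, it also remains open whether removing the hydroxy group from compound 1 would produce a step of similar size, as this single pair cannot show whether the effect carries over to another core.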